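The source may hold more compounds than are shown below. What is called first, only, known or untested is meant among the compounds shown, and "the series" means these compounds.

Working notes on the series. Compound 1 `Cc1cccc(-n2nncc2CN2C(=O)C3(C(C#N)=C(N)Oc4c(N)cc5nc6ccccc6nc5c43)c3ccccc32)c1` carries 3-methylphenyl on the aromatic nitrogen of the triazole ring, and compound 2 `COc1ccc(-n2nncc2CN2C(=O)C3(C(C#N)=C(N)Oc4c(N)cc5nc6ccccc6nc5c43)c3ccccc32)cc1` carries 4-methoxyphenyl at the same position. In a functional assay on A549 cells (Homo sapiens) for antiproliferative activity, read by MTT assay, with a stated time of 48 h (on this read-out higher numbers stand for weaker inhibition and lower numbers for stronger inhibition), compound 1 gives 12300 nM. In this assay compound 2 reaches only the limit of the assay, reported as > 50000 nM. The step of an at least 4.0-fold higher number from compound 1 to compound 2 (0.60 log units; beyond the scatter) is therefore known only as a bound, because of the limit of > 50000 nM in this assay, at which 1 of the 2 values shown sits, the true size of the loss is open.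

Compound 3 `Cc1ccc(C)c(-n2nncc2CN2C(=O)C3(C(C#N)=C(N)Oc4c(N)cc5nc6ccccc6nc5c43)c3ccccc32)c1` is the next member. The change is 2,5-dimethylphenyl in place of 4-methoxyphenyl on an aromatic nitrogen; the methoxy group is removed and two methyl groups are placed on the phenyl. For the measured compounds named here, the only measured step bearing on this is the one from compound 1 to compound 2, which ran the other way, from a methyl-bearing phenyl to a methoxy-bearing one, and was at least modest. Returning to a methyl-bearing phenyl is expected to pull compound 3 back toward the number seen for compound 1, 12300 nM. The expected step is an at least 2.7-fold lower number from compound 2 to compound 3 (0.44 log units; beyond the scatter). Compound 3 is estimated at 18000 nM, with a range from 6000 nM to 60000 nM.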

Compound 3, half-maximal inhibitory concentration: > 50000 nM
Compound 3: no number, only a limit; the forecaster's own chance of this, stated with the estimate: 30%; middle value at least 2.7-fold (0.44 log units) from the limit.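

In this assay compound 3 also gives only a limit of the assay, > 50000 nM, and not a number. One methyl in place of hydrogen on an aromatic carbon of the phenyl is enough for an at least 4.0-fold higher number from compound 1 to compound 3 (0.60 log units; beyond the scatter), so the loss at this position does not need a methoxy group: a phenyl carrying only methyl groups shows it too. The step between compound 2 and compound 3 cannot be read, and the true size of each loss stays open, because of this shared bound: the limit of > 50000 nM in this assay, at which 2 of the 3 values shown sit.

Of the three compounds, only compound 1 gives a number, 12300 nM, so it is not known how far the activity falls once the phenyl changes, or whether any change at this position can give a lower number. The compounds shown also leave open what a phenyl with no substituent, or a phenyl bearing chlorine, a hydroxyl or an amine, would give in this assay.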